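Amine swap on the shared core, receptor binding notes

This account rests on a few compounds, and the source may have more. Where it says the series, first, only, none or still open, it means among the compounds named here.

Measured compounds:
compound 1 `CCC(CC)Nc1nc(C)nc2c(-c3cnc(N(C)C)cc3C)c(C)nn12` gives 24.8 nM in an assay on cell membranes for displacement of a labelled ligand from corticotropin-releasing factor receptor 1 (Rattus norvegicus); a lower number here means a stronger inhibitor, a higher number a weaker inhibitor
compound 2 `CCN(CC)c1nc(C)nc2c(-c3cnc(OC)cc3C)c(C)nn12` gives 14.5 nM in this assay

Compound 2 and compound 1 lie within the scatter of each other in this assay, so compound 2 does not stand apart from compound 1 on these two numbers. Compound 3 `CCC(CC)Nc1nc(C)nc2c(-c3cnc(OC)cc3C)c(C)nn12` differs from compound 2 by (pentan-3-yl)amino in place of diethylamino on an aromatic carbon. Among the measured compounds shown here, the same amine is present in compound 1, which sits within the scatter of compound 2, and no measured pair isolates this change. The expected step is a 1.2-fold higher number from compound 2 to compound 3 (0.09 log units; within the scatter), none beyond the scatter, because compound 1 gives 24.8 nM carrying that amine. Compound 3 is estimated at 18 nM, with a range from 6 nM to 55 nM.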

Compound 3, half-maximal inhibitory concentration: 3 nM
Compound 3: middle estimate off by 6.0-fold (0.78 log units), on the high side; the whole stated range lies above it.
By their numbers in this assay, from the lowest: compound 3; then compounds 2 and 1 (each within the scatter of the next).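

In this assay, the amine on this aromatic carbon matters: (pentan-3-yl)amino in place of diethylamino gives a 4.8-fold lower number from compound 2 to compound 3 (0.68 log units; beyond the scatter). With (pentan-3-yl)amino held fixed, methoxy in place of dimethylamino gives an 8.3-fold lower number from compound 1 to compound 3 (0.92 log units; beyond the scatter), so the closeness of compound 1 and compound 2 concealed two separate effects that offset each other. Nothing available explains either step.

Still open, as far as these compounds go, is whether a smaller secondary amine such as isopropylamino, or a cyclic amine such as morpholine, would hold the binding of compound 3 at this carbon. From the compounds shown here alone, whether ethoxy could replace methoxy is also open.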